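Replacing pyridin-4-yl on the amide nitrogen of compound 3

The source may hold more compounds than are shown below. What is called first, only, known or untested is meant among the compounds shown, and "the series" means these compounds.

Values measured so far in a functional assay on FaDu cells (Homo sapiens) for cytotoxicity, read by MTT assay, with a stated time of 72 h (a lower number here means that less compound is tolerated, a higher number that more compound is tolerated), for the series:
- compound 1 (`COc1ccc(NC(=O)C(=O)c2cn(C(C)C)c3ccccc23)cc1`) gives 181 nM 
- compound 2 (`COCCn1cc(C(=O)C(=O)Nc2ccc(OC(F)(F)F)cc2)c2ccccc21`) gives 487 nM 
- compound 3 (`COCCn1cc(C(=O)C(=O)Nc2ccncc2)c2ccccc21`) gives > 10000 nM as a limit

Compound 3 stands at a limit and has no number (the limit of > 10000 nM in this assay, at which 1 of the 3 values shown sits). Compound 4 (`COCCn1cc(C(=O)C(=O)Nc2ccc(OC)cc2)c2ccccc21`) carries 4-methoxyphenyl in place of pyridin-4-yl on an amide-type nitrogen. Among the compounds with values here, no measured pair differs in one place only. The step expected in this assay is large and runs to a lower number (an at least 40-fold lower number from compound 3 to compound 4 (1.60 log units; beyond the scatter)). That expectation rests on compound 1 (181 nM), which holds the same 4-methoxyphenyl, and on compound 2 (487 nM), which holds the same methoxyethyl chain. Compound 4 is estimated at 250 nM (expected range 70 nM to 900 nM).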

Compound 4, concentration lethal to 50% of the cells: 59 nM
The estimate for compound 4 lay 4.2-fold (0.63 log units) above the measured number; the measured number lies below the stated range.
By their numbers in this assay, from the lowest: compound 4; then compound 1; then compound 2. At a limit, above all of these: compound 3.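

In this assay the group on the amide-type nitrogen gives the largest step, with 4-methoxyphenyl in place of pyridin-4-yl: an at least 160-fold lower number from compound 3 to compound 4 (2.22 log units; beyond the scatter). Compound 3 is a limit and not a number: the limit of > 10000 nM in this assay, at which 1 of the 4 values shown sits.

The other two places give smaller steps, with an 8.3-fold lower number from compound 2 to compound 4 (0.92 log units; beyond the scatter) for methyl in place of trifluoromethyl on the oxygen on the aromatic ring, and a 3.1-fold lower number from compound 1 to compound 4 (0.49 log units; beyond the scatter) for 2-methoxyethyl in place of isopropyl on the aromatic nitrogen.

The compounds shown leave open how an amine or a carboxylic acid would read in place of the methoxy group of 4-methoxyphenyl. They also leave open how a longer chain than 2-methoxyethyl would read on the aromatic nitrogen.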